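The compounds below may be only part of what the source reports. "The series", "measured", "known", "first", "only" and "open" are said of these compounds alone.

Compound 1 `Cc1ccc(-c2cs/c(=N/NC(=O)CSc3nnnn3-c3ccccc3)n2-c2ccccc2)cc1` is one of three compounds built on the same core, differing only in the group attached to the sulfur. In a functional assay on C6 cells (Rattus norvegicus) for cytotoxicity, read by MTT assay, with a stated time of 24 h, tested at 6 ug/mL (a lower number here means a stronger effect, a higher number a weaker effect of the compound at the concentration tested), compound 1 gives 66.8%. Compound 2 `Cc1ccc(-c2cs/c(=N/NC(=O)CSc3ncccn3)n2-c2ccccc2)cc1` gives 93.2%, and compound 3 `Cc1ccc(-c2cs/c(=N/NC(=O)CSc3nnc(C)s3)n2-c2ccccc2)cc1` gives 65.9%. Compound 1 therefore holds the second highest of the three numbers: its nearest neighbour is compound 3, since a number 0.9 percentage points lower from compound 1 to compound 3 (within the scatter), whereas a number 26.4 percentage points higher from compound 1 to compound 2 (beyond the scatter) and a number 27.3 percentage points lower from compound 2 to compound 3 (beyond the scatter).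

Compound 4 `N#Cc1ccc(-c2cs/c(=N/NC(=O)CSc3nnnn3-c3ccccc3)n2-c2ccccc2)cc1` keeps everything of compound 1 except a single spot on the six-membered aromatic ring of carbon only: cyano in place of methyl on an aromatic carbon. Within the data shown here, none of the measured steps touches that ring; all three exchange the group on the sulfur, and they show that such exchanges can move the number by a modest amount or leave it unchanged. For a methyl leaving and a cyano entering on the aromatic carbon there is no precedent among these compounds. With nothing pointing in either direction, the step expected from compound 1 to compound 4 in this assay is a number 0.8 percentage points lower from compound 1 to compound 4 (within the scatter), that is, none beyond the scatter. Compound 4 is accordingly estimated at 66% in this assay. For compound 4 the expected range runs from 48% to 85%.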

Compound 4, a percentage reported as activity, at one concentration (the size of the read-out at that concentration, not a potency): 78.8%
Compound 4: middle estimate off by 12.8 percentage points, on the low side, within the range that was stated.
By their numbers in this assay, from the lowest: compounds 3 and 1 (each within the scatter of the next); then compound 4; then compound 2.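

In this assay, cyano in place of methyl on the aromatic carbon gives a number 12 percentage points higher from compound 1 to compound 4 (beyond the scatter), so the number responds to a change at this spot on the aromatic ring as well as to an exchange of the group on the sulfur. A higher number here means a weaker effect, so with the 1-phenyl-1H-tetrazol-5-yl group kept on the sulfur, 4-cyanophenyl gives a weaker effect than 4-methylphenyl at the one concentration tested. The data offer no measured property that would account for this direction of change.

A single exchange at this spot cannot show how the number would respond to other groups there, such as an amine, a methoxy group or a chlorine atom, or to an unsubstituted phenyl ring. From the compounds shown here alone, it also remains open whether cyano in place of methyl would shift the number in the same direction with the pyrimidin-2-yl or 5-methyl-1,3,4-thiadiazol-2-yl group on the sulfur.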